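Aryl swap at the chain carbon of the guanidinylurea series

The source may hold more compounds than are shown below. What is called first, only, known or untested is meant among the compounds shown, and "the series" means these compounds.

Measured so far:
compound 1 `COc1ccc(C(C)NC(=O)/N=C(\N)NCCCc2sc(N)nc2C)cc1` — 37.2 nM
compound 2 `N/C(=N\C(=O)NCc1ccccc1)NC1CCc2nc(N)sc2C1` — 513 nM
compound 3 `CCCCCCNC(=O)/N=C(\N)NC1CCc2nc(N)sc2C1` — 1120 nM

In an assay on membranes from Sf9 cells for displacement of a labelled ligand from histamine H2 receptor (Homo sapiens), read by scintillation counting, with a stated time of 60 min (on this read-out higher numbers stand for weaker inhibition and lower numbers for stronger inhibition), compound 1 gives the lowest number of the three; compound 2 and compound 3 both sit well beyond the scatter above it, so compound 1 is the strongest inhibitor measured here. Compound 4 `Cc1nc(N)sc1CCCN/C(N)=N/C(=O)NC(C)c1cccs1` is not yet measured. It differs from compound 1 by thiophen-2-yl in place of 4-methoxyphenyl on a saturated chain carbon bound to an amide-type nitrogen and a saturated chain carbon. Among the compounds with values here, the only measured step at this kind of position, a 2.2-fold higher number from compound 2 to compound 3 (0.34 log units; beyond the scatter), replaces an aromatic ring with a chain and gives a modest weakening. The change to compound 4 keeps an aromatic ring at that carbon, so a step no larger than that one is expected, if anything a slight weakening: a 1.6-fold higher number from compound 1 to compound 4 (0.21 log units; within the scatter). Compound 4 is therefore estimated at 60 nM in this assay, in the range 20 nM to 180 nM.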

Compound 4, inhibition constant: 63.1 nM
The estimate for compound 4 lay 1.1-fold (0.02 log units) below the measured number, and the stated range covers the measured number.
By their numbers in this assay, from the lowest: compounds 1 and 4 (each within the scatter of the next); then compound 2; then compound 3.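

In this assay, thiophen-2-yl in place of 4-methoxyphenyl on a saturated chain carbon bound to an amide-type nitrogen and a saturated chain carbon gives a 1.7-fold higher number from compound 1 to compound 4 (0.23 log units; within the scatter). Within the data shown here, this is the first aromatic-for-aromatic exchange, and here a five-membered ring with one hetero atom reads like the six-membered carbon ring bearing methoxy, so this pair shows no loss from the change. No supporting data bear on why the two rings read alike.

Still open, on these data alone, is how unsubstituted phenyl, pyridin-2-yl or a dimethylamine group would read at this carbon.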